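Trimming the Selenocyanate-Bearing Chain of Compound 2

The source may hold more compounds than are shown below. What is called first, only, known or untested is meant among the compounds shown, and "the series" means these compounds.

Within the data shown here, compound 2 `COc1ccc(N(C)c2nc(C)nc3ccccc23)cc1C(=O)OCCC[Se]C#N` gives 250 nM in a functional assay on A549 cells (Homo sapiens) for inhibition, read by MTT assay, with a stated time of 48 h (a lower number here means a stronger inhibitor, a higher number a weaker inhibitor), the highest of the three numbers measured so far. Its nearest neighbour is compound 3 `COc1ccc(N(C)c2nc(C)nc3ccccc23)cc1C(=O)OCCCC[Se]C#N`, which gives 155 nM in this assay; the furthest is compound 1 `Cc1nc(N(C)c2ccc([Se]C#N)c(C)c2)c2ccccc2n1`, which gives 8 nM. Adding one chain carbon yields a 1.6-fold lower number from compound 2 to compound 3 (0.21 log units; within the scatter), so the length of that chain has so far made no difference beyond the scatter.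

Compound 4 `COc1ccc(N(C)c2nc(C)nc3ccccc23)cc1C[Se]C#N` differs from compound 2 as follows: a group of 4 heavy atoms (2 carbon, 1 nitrogen, 1 selenium; no ring) in place of a group of 9 heavy atoms (5 carbon, 1 nitrogen, 2 oxygen, 1 selenium; no ring), on an aromatic carbon. Among the measured compounds shown here, the only measured step that touches the same chain, a 1.6-fold lower number from compound 2 to compound 3 (0.21 log units; within the scatter), concerns lengthening rather than removal and lies within the scatter, so it offers little guidance. Compound 1, with its selenocyanate on an aromatic carbon and a far lower number, differs from compound 2 in more than one place, so it is only a loose pointer toward a lower number. Compound 4 is therefore expected to give 70 nM in this assay, within a range of 18 nM to 280 nM. For compound 4 this estimate implies a 3.6-fold lower number from compound 2 to compound 4 (0.55 log units; beyond the scatter).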

Compound 4, half-maximal inhibitory concentration: 98 nM
Compound 4: middle estimate off by 1.4-fold (0.15 log units), on the low side; measured number inside the range.
By their numbers in this assay, from the lowest: compound 1; then compounds 4, 3 and 2 (each within the scatter of the next, the first and the last beyond it).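

At this position, ortho to a methoxy group, putting the group of 4 heavy atoms in place of the group of 9 heavy atoms in this assay gives a 2.6-fold lower number from compound 2 to compound 4 (0.41 log units; beyond the scatter), the first listed step on this chain to pass beyond the scatter, and it shows that the chain with its carbonyl is not needed for activity in this range. Against the group of 10 heavy atoms the same exchange gives a 1.6-fold lower number from compound 3 to compound 4 (0.20 log units; within the scatter), which stays within the scatter, so the modest gain holds against compound 2 only. Nothing available accounts for this shift.

The compounds shown leave open how an amine, a carboxylic acid or a longer chain would read at this position. They also do not settle what separates compound 4 from compound 1, which differ in more than one place.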